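Acyl Variation and Cytotoxicity on a Shared Core

A few compounds are considered here, and "the series" means these few. Any claim that something is new, unique, unknown or untested is made for them only; others in the source may bear on it.

Measured compounds in an ADME assay on HepG2 2.2.15 cells (Homo sapiens) for cytotoxicity; on this read-out lower numbers stand for higher toxicity in this test and higher numbers for lower toxicity in this test:
Compound 1 `CCCCC(=O)OCCc1c(-c2ccccc2Cl)c2cc(Cl)ccc2[nH]c1=O` gives 200000 nM.
Compound 2 `CCOCC(=O)OCCc1c(-c2ccccc2Cl)c2cc(Cl)ccc2[nH]c1=O` gives 130000 nM.
Compound 3 `O=C(OCCc1c(-c2ccccc2Cl)c2cc(Cl)ccc2[nH]c1=O)C1CCCCC1` gives 38000 nM.

Compound 3 stands lowest of the three numbers, with a 3.4-fold lower number from compound 2 to compound 3 (0.53 log units; beyond the scatter) and a 5.3-fold lower number from compound 1 to compound 3 (0.72 log units; beyond the scatter), both beyond the scatter, so it is the most toxic in this assay. Compound 4 `O=C(OCCc1c(-c2ccccc2Cl)c2cc(Cl)ccc2[nH]c1=O)c1ccccc1` carries phenyl in place of cyclohexyl on a carbonyl carbon. Within the data shown here, no measured step swaps one ring for another; the two known steps that change the group on the carbonyl carbon are modest in size, so a step of similar or smaller size is expected for compound 4, with no clear direction. Compound 4 is therefore estimated near compound 3, at 50000 nM, range 20000 nM to 120000 nM, an expected step of a 1.3-fold higher number from compound 3 to compound 4 (0.12 log units; within the scatter).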

Compound 4, half-maximal cytotoxic concentration: 43000 nM
Compound 4: middle estimate off by 1.2-fold (0.07 log units), on the high side; the measured number falls inside the stated range.
By their numbers in this assay, from the lowest: compounds 3 and 4 (each within the scatter of the next); then compounds 2 and 1 (each within the scatter of the next).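

Swapping the non-aromatic cyclohexyl ring for the aromatic phenyl ring on the carbonyl carbon makes no readable difference in this assay: the result is a 1.1-fold higher number from compound 3 to compound 4 (0.05 log units; within the scatter). Phenyl also sits apart from both open-chain groups, with a 3.0-fold lower number from compound 2 to compound 4 (0.48 log units; beyond the scatter) and a 4.7-fold lower number from compound 1 to compound 4 (0.67 log units; beyond the scatter), so among these four compounds the two with a ring on the carbonyl carbon give the lower numbers, whether or not that ring is aromatic. No available evidence accounts for this result.

Still open, as far as these compounds go, is whether a phenyl ring bearing a chlorine, or a pyridine ring, would stay at this level. An amine on the acyl chain is equally untested in the compounds shown here.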